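The source may hold more compounds than are shown below. What is called first, only, known or untested is meant among the compounds shown, and "the series" means these compounds.

The three measured compounds, each with its result in a functional assay on A549 cells (Homo sapiens) for cytotoxicity, read by MTT assay, with a stated time of 72 h; on this read-out higher numbers stand for weaker inhibition and lower numbers for stronger inhibition:
compound 1 `COc1cc2c(Oc3ccc(NC(=O)N/N=C/c4ccc([N+](=O)[O-])cc4)cc3F)ccnc2cc1OCCCN1CCCC1` gives 460 nM;
compound 2 `COc1cc2c(Oc3ccc(NC(=O)N/N=C/c4ccc(C(F)(F)F)cc4)cc3F)ccnc2cc1OCCCN1CCCC1` gives 790 nM;
compound 3 `COc1cc2c(Oc3ccc(NC(=O)N/N=C/c4ccc(F)cc4Cl)cc3F)ccnc2cc1OCCCN1CCCCC1` gives 130 nM.

Compound 3 stands lowest of the three numbers, and its gaps to compound 1 and to compound 2 are both beyond the usual scatter. Compound 4 `COc1ccc(/C=N/NC(=O)Nc2ccc(Oc3ccnc4cc(OCCCN5CCCCC5)c(OC)cc34)c(F)c2)c(OC)c1` has not yet been tested in this assay. It differs from compound 3 in one place: 2,4-dimethoxyphenyl in place of 2-chloro-4-fluorophenyl on a carbon with a double bond to nitrogen. Going by the values given here, only one measured step exists, a 1.7-fold higher number from compound 1 to compound 2 (0.23 log units; within the scatter), which exchanges a single group within the same part of the structure that is replaced as a whole on the way to compound 4, and that step lies within the scatter. It does not involve the groups exchanged here, so it is only a loose guide: one change in this region did not move the number much. For compound 4 the expected step is therefore a 1.9-fold higher number from compound 3 to compound 4 (0.28 log units; within the scatter), a modest rise that may still fall within the scatter. Compound 4 is expected to give 250 nM in this assay, with a range from 80 nM to 800 nM.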

Compound 4, half-maximal inhibitory concentration: 1400 nM
Compound 4: the middle estimate sits 5.6-fold (0.75 log units) below what was measured, and the stated range ends below it.
By their numbers in this assay, from the lowest: compound 3; then compounds 1, 2 and 4 (each within the scatter of the next, the first and the last beyond it).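

In this assay, replacing the whole aromatic group on the carbon with a double bond to nitrogen can change the result sharply: 2,4-dimethoxyphenyl in place of 2-chloro-4-fluorophenyl gives an 11-fold higher number from compound 3 to compound 4 (1.03 log units; beyond the scatter), which means clearly weaker inhibition. Going by these compounds alone, the only earlier step in this part of the structure, a 1.7-fold higher number from compound 1 to compound 2 (0.23 log units; within the scatter), exchanged a single group and stayed within the scatter, so it gave no sign that this region could be so sensitive to the groups it carries. Nothing measured here explains the rise, and the structural differences between the two groups describe the change without accounting for it.

Because the step removes both the chlorine and the fluorine and adds two methoxy groups at once, these compounds cannot show whether the loss of the halogens, the arrival of the methoxy groups or one methoxy group alone accounts for most of the change. As far as these compounds go, it also remains open how this region would respond to other groups on the aromatic ring, such as a hydroxyl group or a dimethylamino group, and whether any of them would keep the result near that of compound 3 at 130 nM.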